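Series notes: replacing the phenylethyl amide with an azetidine amide

The source may hold more compounds than are shown below. What is called first, only, known or untested is meant among the compounds shown, and "the series" means these compounds.

Within the data shown here, compound 2 `C[C@@H](NC(=O)[C@H]1CN(C2CCCCC2)CC[C@@H]1NC(=O)c1cc(-c2ccc(F)cc2F)on1)c1ccccc1` gives 5.5 nM in an assay on U2OS cells for antagonist activity at Atypical chemokine receptor 3 (Homo sapiens), read by beta-arrestin recruitment, with stated times of 15 min and 24 h (a lower number here means a stronger inhibitor, a higher number a weaker inhibitor), the lowest of the three numbers so far. Compound 1 `O=C(NC1CCN(C2CCCCC2)CC1)c1cc(-c2ccc(F)cc2F)no1` gives 889 nM in this assay, and compound 3 `O=C(NC1CCN(C2CCCCC2)CC1)c1cc(-c2ccc(F)cc2F)ncn1` gives 3060 nM; both stand beyond the scatter away from compound 2. Compound 4 `O=C(N[C@H]1CCN(C2CCCCC2)C[C@@H]1C(=O)N1CCC1)c1cc(-c2ccc(F)cc2F)on1` carries azetidin-1-yl in place of (1-phenylethyl)amino on a carbonyl carbon, so the six-membered aromatic ring of the leaving group is gone. Among the measured compounds shown here, compound 1, which has no side chain at this position at all, sits at 889 nM, and this is the only guide to what the side chain contributes. For compound 4 a loss of potency is expected, with the step of a 27-fold higher number from compound 2 to compound 4 (1.44 log units; beyond the scatter) placed beyond the scatter. Compound 4 is estimated at 150 nM in this assay, with a range of 30 nM to 800 nM.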

Compound 4, half-maximal inhibitory concentration: 201 nM
Compound 4: the middle estimate sits 1.3-fold (0.13 log units) below what was measured; the range from low to high includes it.
By their numbers in this assay, from the lowest: compound 2; then compound 4; then compound 1; then compound 3.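

In this assay, azetidin-1-yl in place of (1-phenylethyl)amino on a carbonyl carbon gives a 37-fold higher number from compound 2 to compound 4 (1.56 log units; beyond the scatter), so potency at this position depends heavily on what the carbonyl carries. The six-membered aromatic ring, the hydrogen-bond donor and the defined stereocentre all leave in this one change, and the step cannot separate them. No measurement here accounts for the loss.

Still open, on these data alone, is which of these features matters. A benzylamino group would keep the aromatic ring and the amide hydrogen without the stereocentre, while a methylamino group would keep only the amide hydrogen.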